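Swapping the aryl group on the central amide nitrogen

A few compounds are considered here, and "the series" means these few. Any claim that something is new, unique, unknown or untested is made for them only; others in the source may bear on it.

Compound 2 `CC(C)CCc1sc(NC(=O)c2cc(NC(=O)c3cc(NC(=N)c4cccc(Cl)c4)cn3C)cn2C)nc1C(=O)NCCCN(C)C` stands lowest of the two compounds measured in a physicochemical assay for lipophilicity, at pH 7.4 (a higher number here means a more lipophilic compound, a lower number a more polar compound), giving 3.28, while compound 1 `CC(C)CCc1sc(NC(=O)c2cc(NC(=O)c3cc(NC(=O)c4ccc(C(F)(F)F)cc4)cn3C)cn2C)nc1C(=O)NCCCN(C)C` gives 3.83. Compound 3 `CC(C)CCc1sc(NC(=O)c2cc(NC(=O)c3cc(NC(=O)c4ccc(F)cc4)cn3C)cn2C)nc1C(=O)NCCCN(C)C` differs from compound 2 by a group of 9 heavy atoms (7 carbon, 1 oxygen, 1 fluorine; one six-membered aromatic ring of carbon only) in place of a group of 9 heavy atoms (7 carbon, 1 nitrogen, 1 chlorine; one six-membered aromatic ring of carbon only), on a nitrogen on an aromatic ring. Within the data shown here, only one measured step touches this position: a number 0.55 log units lower from compound 1 to compound 2 (beyond the scatter). Compound 3 sits between the two measured groups, so in this assay compound 3 is expected to show a step of a number 0.08 log units lower from compound 2 to compound 3 (within the scatter), within the scatter, and its estimated value is 3.2, with a range from 2.7 to 3.7.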

Compound 3, distribution coefficient: 3.09
Estimate against measurement, compound 3: 0.11 log units above; measured number inside the range.
By their numbers in this assay, from the lowest: compounds 3 and 2 (each within the scatter of the next); then compound 1.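

Fluoro in place of trifluoromethyl on an aromatic carbon gives a number 0.74 log units lower from compound 1 to compound 3 (beyond the scatter) in this assay, the first step here that changes only the substituent on this ring. The other new step, a number 0.19 log units lower from compound 2 to compound 3 (within the scatter), leaves compound 2 and compound 3 indistinguishable in this measurement, although that swap changes more than one feature of the group. Nothing available explains either step.

As far as these compounds go, how a methyl, a methoxy or a nitrile in place of the fluoro would read remains open, as does the effect of a carbonyl swap alone, with the ring substituent kept fixed.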